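Swapping Methylsulfanyl for Methylcarbamoyl on the Shared Core

The source may hold more compounds than are shown below. What is called first, only, known or untested is meant among the compounds shown, and "the series" means these compounds.

Compound 1, `CC(C)(C)C(=O)c1coc(C(=O)CCCCCCc2ccccc2)n1`, gives 479 nM in an assay on HEK-293T cells for inhibition of diacylglycerol lipase-alpha (Homo sapiens), read by colorimetric assay; on this read-out lower numbers stand for stronger inhibition and higher numbers for weaker inhibition.
Compound 2, `O=C(CCCCCCc1ccccc1)c1nc(Cl)co1`, gives 2400 nM in this assay.
Compound 3, `CSc1coc(C(=O)CCCCCCc2ccccc2)n1`, gives > 10000 nM in this assay; this is a limit of the assay and not a number.

Compound 3 therefore stands at the weak end of the three, at the limit of > 10000 nM in this assay, at which 1 of the 3 values shown sits. Both measured steps that lead into it lose potency: an at least 20-fold higher number from compound 1 to compound 3 (1.31 log units; beyond the scatter) is the largest change in the set, and an at least 4.1-fold higher number from compound 2 to compound 3 (0.61 log units; beyond the scatter) is at least modest. Between the two compounds with real numbers, a 5.0-fold higher number from compound 1 to compound 2 (0.70 log units; beyond the scatter) shows that the (tert-butyl)carbonyl group of compound 1 gives the lowest number seen here.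

Compound 4, `CNC(=O)c1coc(C(=O)CCCCCCc2ccccc2)n1`, is compound 3 with methylcarbamoyl in place of methylsulfanyl on an aromatic carbon. Like compound 1, it carries a carbonyl on that carbon of the shared core, whereas compound 3 carries a sulfur-linked methyl group there. Every measured step away from methylsulfanyl lowered the number, so compound 4 is expected to improve on compound 3 by an at least 8.3-fold lower number from compound 3 to compound 4 (0.92 log units; beyond the scatter). The estimate for compound 4 in this assay is 1200 nM, with a range from 250 nM to 7000 nM.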

Compound 4, half-maximal inhibitory concentration: > 10000 nM
Compound 4: no number, only a limit; the forecaster's own chance of this, stated with the estimate: 15%; middle value at least 8.3-fold (0.92 log units) away from the limit.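

The result for compound 4 is a limit of the assay and not a number, as is the result for compound 3, so the step between these two cannot be read: the limit of > 10000 nM in this assay, at which 2 of the 4 values shown sit. A carbonyl on this carbon of the shared core is clearly not enough by itself, since putting methylamino in place of tert-butyl on that carbonyl carbon gives an at least 20-fold higher number from compound 1 to compound 4 (1.31 log units; beyond the scatter), so what is attached to the carbonyl matters in this assay. The methylcarbamoyl group also falls behind a single chloro at this place, with an at least 4.1-fold higher number from compound 2 to compound 4 (0.61 log units; beyond the scatter), so among these compounds only the (tert-butyl)carbonyl and chloro groups give readable values.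

The two limits leave open how weak compound 3 and compound 4 really are, and which of the two groups is the poorer one. On these data alone, it also remains open whether the loss in compound 4 follows from the amide hydrogen or from the missing tert-butyl group, a question that a dimethylcarbamoyl or an isopropylcarbonyl group on this carbon could help to separate.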